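The source may report more compounds than this note shows. Statements on the series, on what has been measured and on what is new or still open speak of the compounds shown alone.

Of the compounds shown here, three have been measured in an assay on a cell-free system (plasma) for inhibition of Dipeptidyl peptidase 4 (Rattus norvegicus), read by fluorescence; a higher number here means a weaker inhibitor, a lower number a stronger inhibitor. Compound 1 `COCc1nsc(N2CCN(C(=O)[C@@H]3CN[C@H](C(=O)N4CCCC4)C3)CC2)n1` gives 49 nM. Within the data shown here, compound 2 `Cc1ncc(N2CCN(C(=O)[C@@H]3CN[C@H](C(=O)N4CCCC4)C3)CC2)s1` gives 340 nM; the only single-point step among the measured pair, a 6.9-fold higher number from compound 1 to compound 2 (0.84 log units; beyond the scatter), concerns the aromatic ring on the amine nitrogen of the shared core. Compound 3 `Cc1nsc(N2CCN(C(=O)[C@H]3C[C@@H](C(=O)N4CCCC4)N[C@H]3C)CC2)n1` gives 69 nM, the second highest of the three numbers, with compound 1 nearest and within the scatter and compound 2 furthest and beyond it.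

Compound 4 `Cc1nsc(N2CCN(C(=O)[C@H]3C[C@@H](C(=O)N4CCSC4)N[C@H]3C)CC2)n1` is not yet measured. Compared with compound 3 it differs in one place: 1,3-thiazolidin-3-yl in place of pyrrolidin-1-yl on a carbonyl carbon. Among the measured compounds shown here, no measured step touches this part of the molecule; the one step on record changes a different ring, so it offers no guide to the direction or size here. With nothing in the data pointing either way, the change is expected to move the number little, and the estimated step of a 1.2-fold higher number from compound 3 to compound 4 (0.06 log units; within the scatter) is expected to lie within the scatter. Compound 4 is therefore estimated at 80 nM, with a range from 35 nM to 180 nM.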

Compound 4, half-maximal inhibitory concentration: 60 nM
Estimate against measurement, compound 4: 1.3-fold (0.12 log units) above, and the stated range covers the measured number.
By their numbers in this assay, from the lowest: compounds 1, 4 and 3 (each within the scatter of the next); then compound 2.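

In this assay the change on the carbonyl carbon gives a 1.2-fold lower number from compound 3 to compound 4 (0.06 log units; within the scatter) and so does not separate 1,3-thiazolidin-3-yl from pyrrolidin-1-yl. Among these compounds, this is the first reading on this part of the molecule, since the earlier step concerned a different ring. It shows that this ring can carry a second hetero atom, a sulfur, with the five-membered ring size kept and the number still within the scatter, and no further data bear on this result.

Still open, as far as these compounds go, is whether a six-membered piperidin-1-yl ring or an open-chain diethylamino group on the same carbonyl carbon would also leave the number in place. Also open, from the compounds shown here alone, is whether 1,3-thiazolidin-3-yl would read the same on the core of compound 1.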